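Amide-nitrogen substituents on the shared core

This account rests on a few compounds, and the source may have more. Where it says the series, first, only, none or still open, it means among the compounds named here.

Working notes on a short series. In a functional assay on HepG2 cells (Homo sapiens) for antiproliferative activity, read by MTT assay (a lower number here means a stronger inhibitor, a higher number a weaker inhibitor), compound 2 `Nc1c(C(=O)NC2CCCC2)oc2nc(-c3ccccc3)cc(C(F)(F)F)c12` gives 32400 nM, the highest of the three numbers recorded; compound 3 `CNC(=O)c1oc2nc(-c3cccs3)cc(C(F)(F)F)c2c1N` gives 12300 nM and compound 1 `Nc1c(C(=O)N/N=C/c2ccc(Br)cc2)oc2nc(-c3cccs3)cc(C(F)(F)F)c12` gives 6100 nM, both beyond the scatter below compound 2. Compound 4 `Nc1c(C(=O)N/N=C/c2ccc(Cl)cc2)oc2nc(-c3ccccc3)cc(C(F)(F)F)c12` has not been measured in this assay. It differs from compound 2 by a group of 9 heavy atoms (7 carbon, 1 nitrogen, 1 chlorine; one six-membered aromatic ring of carbon only) in place of a group of 5 heavy atoms (5 carbon; one five-membered non-aromatic ring of carbon only), on an amide-type nitrogen. Among the compounds with values here, only one measured step changes the same position: a 2.0-fold higher number from compound 1 to compound 3 (0.30 log units; within the scatter), where a group of 9 heavy atoms on the amide-type nitrogen was replaced by a single carbon atom and the number moved within the scatter. Within the data shown here, that step was made on a core that differs from the one of compound 2 elsewhere, so it bears on the present change only indirectly. Among the measured compounds shown here, compound 1, the one compound carrying a 9-heavy-atom group of this kind on the amide-type nitrogen, stands lowest, while compound 2 with its cyclopentyl stands highest; those two values, however, differ in two places at once. The change from compound 2 to compound 4 is therefore expected to give a lower number in this assay, a 2.7-fold lower number from compound 2 to compound 4 (0.43 log units; beyond the scatter), of moderate size. For compound 4 the estimate is 12000 nM, with a range from 5000 nM to 30000 nM.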

Compound 4, half-maximal inhibitory concentration: 12100 nM
The estimate for compound 4 lay 1.0-fold (0.00 log units) below the measured number, and the stated range covers the measured number.
By their numbers in this assay, from the lowest: compounds 1, 4 and 3 (each within the scatter of the next); then compound 2.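

In this assay, within the data shown here, a 2.7-fold lower number from compound 2 to compound 4 (0.43 log units; beyond the scatter) gives the first change at the amide-type nitrogen that lies beyond the scatter, whereas the only earlier step at this place, a 2.0-fold higher number from compound 1 to compound 3 (0.30 log units; within the scatter), stayed within it. The number at this place can therefore respond to the substituent, at least on the core of compound 2, where a cyclopentyl gives way to the larger group carrying a six-membered aromatic ring, a chlorine and a double bond outside aromatic rings. Nothing available explains this shift.

Among these compounds, the single step changes all of these features together, so it does not show which of them matters, or whether the same exchange would hold on the core of compound 1. On these data alone, how a plain phenyl, a morpholine or a longer alkyl chain on this nitrogen would compare also remains open.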